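The compounds below may be only part of what the source reports. "The series", "measured", "known", "first", "only" and "open" are said of these compounds alone.

Three compounds share one core and differ only in the group on the pyridine carbon. In an assay on membranes from brain for binding affinity to Lysophosphatidylserine lipase ABHD12 (Mus musculus), read by fluorescence, with a stated time of 20 min (a higher number here means a weaker inhibitor, a lower number a stronger inhibitor), compound 1 `S=C(Nc1cccnc1)NC1CCN(c2cc(OCc3ccccc3)ccn2)CC1` gives 2800 nM, compound 2 `FC(F)(F)c1ccnc(N2CCC(NC(=S)Nc3cccnc3)CC2)c1` gives 640 nM, and compound 3 `S=C(Nc1cccnc1)NC1CCN(c2cc(OC3CCCCC3)ccn2)CC1` gives 3400 nM. Compound 3 thus carries the highest of the three numbers, though the step of a 1.2-fold higher number from compound 1 to compound 3 (0.08 log units; within the scatter) is within the scatter, while a 5.3-fold higher number from compound 2 to compound 3 (0.73 log units; beyond the scatter) is beyond it.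

Compound 4 `Fc1ccc(Oc2ccnc(N3CCC(NC(=S)Nc4cccnc4)CC3)c2)cc1` differs from compound 3 by 4-fluorophenyl in place of cyclohexyl on an oxygen on an aromatic ring. Among the compounds with values here, the one measured step that bears directly on this change is the swap of a benzyl for a cyclohexyl on the same oxygen, a 1.2-fold higher number from compound 1 to compound 3 (0.08 log units; within the scatter), which stayed within the scatter; the steps of a 4.4-fold lower number from compound 1 to compound 2 (0.64 log units; beyond the scatter) and a 5.3-fold higher number from compound 2 to compound 3 (0.73 log units; beyond the scatter) involve the trifluoromethyl and speak less directly. On that basis, compound 4 is expected to show no change beyond the scatter in this assay, an estimated step of a 1.3-fold lower number from compound 3 to compound 4 (0.12 log units; within the scatter). Compound 4 is therefore estimated at 2600 nM, with a range from 900 nM to 7500 nM.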

Compound 4, half-maximal inhibitory concentration: 1400 nM
Compound 4: middle estimate off by 1.9-fold (0.27 log units), on the high side, and the stated range covers the measured number.
By their numbers in this assay, from the lowest: compound 2; then compounds 4, 1 and 3 (each within the scatter of the next, the first and the last beyond it).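

What sits on the oxygen does matter: replacing the non-aromatic cyclohexyl with the aromatic 4-fluorophenyl gives a step beyond the scatter (a 2.4-fold lower number from compound 3 to compound 4 (0.39 log units; beyond the scatter)), which the earlier swap between benzyl and cyclohexyl did not. Even so, 4-fluorophenyl and benzyl on this oxygen cannot be told apart (a 2.0-fold lower number from compound 1 to compound 4 (0.30 log units; within the scatter)), and the ether in compound 4 does not match trifluoromethyl on the aromatic carbon (a 2.2-fold higher number from compound 2 to compound 4 (0.34 log units; beyond the scatter)). Nothing available explains why the aromatic ring gives the lower number here.

On these data alone, it remains open whether plain phenyl, without the fluorine, would behave like 4-fluorophenyl, or whether the fluorine contributes to the step. Also open, as far as these compounds go, is how an amine or a carboxylic acid on that aromatic ring would compare.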